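The source may hold more compounds than are shown below. What is called first, only, known or untested is meant among the compounds shown, and "the series" means these compounds.

Compound 1 `NCCCC[C@H](NC(=O)CN(c1nc(Cl)nc2[nH]cnc12)C1CC1)C(=O)OCc1ccccc1` was tested in a functional assay on the whole organism (Tail, strain ICR) with Mus musculus as the target, in the tail flick test, with a stated time of 30 min, at a dose of 25 umol/kg by the oral route (on this read-out higher numbers stand for a stronger effect at the one dose given and lower numbers for a weaker effect), where compound 1 gives 26.1%. Compound 2 `CSCC[C@H](NC(=O)CN(c1ncnc2c1ncn2C1CCCCO1)C1CC1)C(=O)OCc1ccccc1` gives 30% in this assay, a number that lies within the scatter of that of compound 1, so the two stand level on the numbers shown. Compound 3 `NC(=O)CC[C@H](NC(=O)CN(c1nc(Cl)nc2[nH]cnc12)C1CC1)C(=O)OCc1ccccc1` has not yet been measured. It differs from compound 1 by carbamoyl in place of 2-aminoethyl on a saturated chain carbon, three bonds along the chain from an amide-type nitrogen and a carbonyl carbon. Going by the values given here, no measured pair shows this change; the step expected, a number 1.1 percentage points lower from compound 1 to compound 3 (within the scatter), is small, without a clear direction, and need not exceed the scatter. Compound 3 is therefore estimated at 25%, within a range from 10% to 42%.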

Compound 3, a percentage reported as activity, at one dose (the size of the read-out at that dose, not a potency): 30.8%
Compound 3: middle estimate off by 5.8 percentage points, on the low side, within the range that was stated.
By their numbers in this assay, from the lowest: compounds 1, 2 and 3 (each within the scatter of the next).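

In this assay, going by these compounds alone, carbamoyl in place of 2-aminoethyl on this saturated chain carbon gives a number 4.7 percentage points higher from compound 1 to compound 3 (within the scatter), the first step that can be read at this position. Compound 1 and compound 3 therefore stand level, and this change at this carbon does not separate them on the read-out. Nothing available bears on why the two stand level. The compounds shown leave open whether a carboxylic acid or a longer chain on this carbon would also stay level with compound 1. They also leave open whether this change would give a similar step on a different core.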